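Adding a Methoxy Group to a Chromone Core

A few compounds are considered here, and "the series" means these few. Any claim that something is new, unique, unknown or untested is made for them only; others in the source may bear on it.

- compound 1 `COc1cc(OC)c2c(=O)cc(C3(O)C=CC(=O)C=C3)oc2c1`: 1210 nM
- compound 2 `O=C1C=CC(O)(c2cc(=O)c3c(O)cccc3o2)C=C1`: 3440 nM

Of the compounds shown here, two have been tested in a functional assay on MCF7 cells (Homo sapiens) for cytotoxicity, read by colorimetric assay and MTT assay, with a stated time of 72 h; on this read-out lower numbers stand for stronger inhibition and higher numbers for weaker inhibition. Going by the values given here, compound 2 gives 3440 nM, the higher of the two numbers; the only other measured compound, compound 1, gives 1210 nM, a lower number, and the gap between them lies beyond the usual scatter.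

Compound 3 `COc1cc(O)c2c(=O)cc(C3(O)C=CC(=O)C=C3)oc2c1` has not yet been measured. It differs from compound 2 in one place: methoxy in place of hydrogen on an aromatic carbon. No direct comparison between measured compounds isolates this change, so the expectation can only rest on where compound 1 and compound 2 stand. Compound 3 carries one methoxy group, where compound 1 carries two and compound 2 carries none, so a number between them seems plausible. The step from compound 2 is expected to be a 1.7-fold lower number from compound 2 to compound 3 (0.24 log units; within the scatter), a modest move toward lower numbers. For compound 3 the estimate is 2000 nM, with a range from 800 nM to 5000 nM.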

Compound 3, half-maximal inhibitory concentration: 1700 nM
Estimate against measurement, compound 3: 1.2-fold (0.07 log units) above; the measured number falls inside the stated range.
By their numbers in this assay, from the lowest: compounds 1 and 3 (each within the scatter of the next); then compound 2.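

In this assay, going by these compounds alone, methoxy in place of hydrogen on this aromatic carbon, meta to a hydroxy group, gives a 2.0-fold lower number from compound 2 to compound 3 (0.31 log units; beyond the scatter), which is the first direct reading of this change and lies just beyond the scatter. The other single change, hydrogen in place of methyl on an oxygen on an aromatic ring, gives a 1.4-fold higher number from compound 1 to compound 3 (0.15 log units; within the scatter), so these two numbers cannot be told apart in this assay. Nothing measured here explains either step.

The compounds shown leave open how a longer chain such as ethoxy, an amine or a carboxylic acid on this same aromatic carbon would compare with methoxy. They also leave open whether the methoxy step would hold on any other cell line.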